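Amide substituent variation on the shared core

This account rests on a few compounds, and the source may have more. Where it says the series, first, only, none or still open, it means among the compounds named here.

The shared core is carried unchanged through the series; compound 1 `COc1cc2c(cc1OC)C(CC(=O)N(C)C)CC2` bears a dimethylamino group on the carbonyl carbon, compound 2 `COc1cc2c(cc1OC)C(CC(=O)NC(C)(C)C)CC2` a (tert-butyl)amino group, and compound 3 `CCCCCNC(=O)CC1CCc2cc(OC)c(OC)cc21` a pentylamino group. In a functional assay on the whole organism (strain Wistar) for inhibition, with Rattus norvegicus as the target, read by paw edema, with stated times of 60 min and 2 h, at a dose of 100 mg/kg by the oral route (on this read-out higher numbers stand for more inhibition at the one dose given (going by the name of the read-out) and lower numbers for less inhibition), compound 1 gives 36%, compound 2 gives 32% and compound 3 gives 34%. On the numbers shown compound 3 sits between the other two, separated from each by a step within the scatter: a number 2 percentage points lower from compound 1 to compound 3 (within the scatter) and a number 2 percentage points higher from compound 2 to compound 3 (within the scatter). Compound 4 `CCCCCCNC(=O)CC1CCc2cc(OC)c(OC)cc21` differs from compound 3 by methyl in place of hydrogen on a saturated chain carbon, five bonds along the chain from an amide-type nitrogen. Among the measured compounds shown here, the steps that bear on this are the exchanges at the same nitrogen, a number 2 percentage points higher from compound 2 to compound 3 (within the scatter) and a number 2 percentage points lower from compound 1 to compound 3 (within the scatter); neither moved the read-out beyond the scatter, and the present change is smaller than either of them. No step beyond the scatter is therefore expected in this assay, that is no change at the digits printed from compound 3 to compound 4 (within the scatter). Compound 4 is estimated at 34%, with a range from 24% to 44%.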

Compound 4, a percentage reported as inhibition, in the whole organism at one dose (the size of the read-out at that dose, not a potency): 41.5%
Beside the measured number, compound 4's estimate is 7.5 percentage points below it; measured number inside the range.
By their numbers in this assay, from the lowest: compounds 2, 3, 1 and 4 (each within the scatter of the next).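

At the saturated chain carbon five bonds along the chain from an amide-type nitrogen, methyl in place of hydrogen gives a number 7.5 percentage points higher from compound 3 to compound 4 (within the scatter) in this assay. Hexyl is therefore accepted on this nitrogen, and the series still shows no step beyond the scatter: the exchange for tert-butyl gives a number 9.5 percentage points higher from compound 2 to compound 4 (within the scatter) and the exchange of hexylamino for dimethylamino gives a number 5.5 percentage points higher from compound 1 to compound 4 (within the scatter). No evidence is available on what lies behind these steps.

On these data alone, whether a longer chain such as octyl moves the read-out beyond the scatter remains open. So does the effect of a chain that ends in a carboxylic acid or an amine rather than in methyl.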